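Swapping the amine-bearing amide chain for an allyl(methyl)amide

The compounds below may be only part of what the source reports. "The series", "measured", "known", "first", "only" and "open" are said of these compounds alone.

Compound 1, `CC[C@@H](C)[C@H](NC(=O)c1ccc(C(CC)(CC)c2ccc(OCC(O)C(C)(C)C)c(C)c2)n1CC)C(=O)OC`: 26 nM
Compound 2, `C#CCNC(=O)c1ccc(C(CC)(CC)c2ccc(OCC(O)C(C)(C)C)c(C)c2)n1CC`: 240 nM
Compound 3, `CCn1c(C(=O)NCCN)ccc1C(CC)(CC)c1ccc(OCC(O)C(C)(C)C)c(C)c1`: 10 nM

In an assay on HL-60 cells for agonist activity at vitamin D3 receptor (Homo sapiens), read by microscopy, with a stated time of 96 h (on this read-out lower numbers stand for an effect already at smaller amounts and higher numbers for an effect only at larger amounts of compound), compound 3 gives the lowest of the three numbers. The steps of a 2.6-fold lower number from compound 1 to compound 3 (0.41 log units; beyond the scatter) and a 24-fold lower number from compound 2 to compound 3 (1.38 log units; beyond the scatter) place it beyond the scatter of both neighbours, with compound 2 the furthest away.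

Compound 4, `C=CCN(C)C(=O)c1ccc(C(CC)(CC)c2ccc(OCC(O)C(C)(C)C)c(C)c2)n1CC`, differs from compound 3 by allyl(methyl)amino in place of (2-aminoethyl)amino on a carbonyl carbon. The step that bears most directly on this is a 24-fold lower number from compound 2 to compound 3 (1.38 log units; beyond the scatter): putting an amine onto the chain on the amide nitrogen lowered the number by a large amount, and compound 4 gives that amine up again, keeping only a short hydrocarbon chain, much as compound 2 does. Among the compounds with values here, compound 4 additionally loses the amide hydrogen, a change no measured pair covers, so the expected size carries extra uncertainty. A step of about a 30-fold higher number from compound 3 to compound 4 (1.48 log units; beyond the scatter) is expected, toward higher numbers. Compound 4 is estimated to give 300 nM, within a range of 80 nM to 1200 nM.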

Compound 4, half-maximal effective concentration: 3950 nM
Estimate against measurement, compound 4: 13-fold (1.12 log units) below; the measured number lies above the stated range.
By their numbers in this assay, from the lowest: compound 3; then compound 1; then compound 2; then compound 4.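

In this assay, the step of a 400-fold higher number from compound 3 to compound 4 (2.60 log units; beyond the scatter) is the largest seen at this position, so the amide substituent on the carbonyl carbon matters more than the first three compounds showed. Losing the amine chain is not the whole story: the step of a 16-fold higher number from compound 2 to compound 4 (1.22 log units; beyond the scatter) separates compound 4 from a compound that also has a short hydrocarbon chain and no amine, and the step of a 150-fold higher number from compound 1 to compound 4 (2.18 log units; beyond the scatter) shows the same direction, while compound 4 alone lacks the amide hydrogen. Nothing measured here explains why the number rises so far.

Going by these compounds, it remains open whether the rise follows the methyl group on the amide nitrogen, the allyl chain or both, as compound 4 changes these together. On these data alone, how a longer chain carrying an amine or a carboxylic acid would behave at this position also remains open.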